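The compounds below may be only part of what the source reports. "The series", "measured", "known", "first", "only" and "open" are said of these compounds alone.

Measured compounds:
compound 1 `COC1NN=C(C[S+]([O-])C(c2ccccc2)c2ccccc2)S1` — 108000 nM
compound 2 `CC(C)c1nnsc1C[S+]([O-])C(c1ccccc1)c1ccccc1` — 69100 nM
compound 3 `[O-][S+](Cc1cc(C2CC2)on1)C(c1ccccc1)c1ccccc1` — 38600 nM

The three compounds share a core and differ only in the group on a saturated chain carbon bound to a sulfur. In an assay on HEK293 cells for inhibition of sodium-dependent dopamine transporter (Homo sapiens), read by scintillation counting, with stated times of 5 min and 1 min (on this read-out higher numbers stand for weaker inhibition and lower numbers for stronger inhibition), compound 3 gives the lowest of the three numbers. Its nearest neighbour is compound 2, and the step of a 1.8-fold lower number from compound 2 to compound 3 (0.25 log units; within the scatter) is within the scatter; the step from compound 1 is larger, a 2.8-fold lower number from compound 1 to compound 3 (0.45 log units; beyond the scatter), and modest. The remaining step, a 1.6-fold lower number from compound 1 to compound 2 (0.19 log units; within the scatter), is within the scatter.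

Compound 4 `[O-][S+](Cc1ccsc1Br)C(c1ccccc1)c1ccccc1` is not yet measured in this assay. The change is 2-bromothiophen-3-yl in place of 5-cyclopropyl-1,2-oxazol-3-yl on a saturated chain carbon bound to a sulfur. All three measured steps bear on it, since each swaps one small heteroaryl group at this same position for another, and none moved the number by more than a modest amount. Compound 4 is therefore expected to stay close to compound 3, with a step of a 1.1-fold lower number from compound 3 to compound 4 (0.04 log units; within the scatter) that need not exceed the scatter. The estimate for compound 4 is 35000 nM, in a range from 12000 nM to 100000 nM.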

Compound 4, half-maximal inhibitory concentration: 29300 nM
Compound 4: middle estimate off by 1.2-fold (0.08 log units), on the high side, and the stated range covers the measured number.
By their numbers in this assay, from the lowest: compounds 4, 3, 2 and 1 (each within the scatter of the next, the first and the last beyond it).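

In this assay, putting 2-bromothiophen-3-yl on the saturated chain carbon bound to a sulfur, with fewer heavy atoms, a single ring and one hydrogen-bond acceptor in place of two, gives a 1.3-fold lower number from compound 3 to compound 4 (0.12 log units; within the scatter) and so shows that a group with no ring nitrogen or oxygen and with a bromine can sit here with the number still within the scatter of compound 3. The same group gives a 2.4-fold lower number from compound 2 to compound 4 (0.37 log units; beyond the scatter) and a 3.7-fold lower number from compound 1 to compound 4 (0.57 log units; beyond the scatter), and even this last and widest step among the four compounds remains modest. No independent measurement bears on why the number shifts at this position.

The compounds shown leave open whether the bromine counts for anything, or whether a plain thiophen-3-yl or a chlorine in its place would give the same number. They also leave open whether a group without a five-membered ring, such as an amine, a carboxylic acid or a longer chain, would move the number further.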